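A Chloro-for-Methoxy Swap Beside Two Unreadable Limits

This account rests on a few compounds, and the source may have more. Where it says the series, first, only, none or still open, it means among the compounds named here.

Compound 1 `COc1ccc(NC(=O)COC(=O)/C=C/c2cc(OC)c(OCc3ccc(Cl)c(Cl)c3)c(OC)c2)cc1` was examined in a functional assay on PC-3 cells (Homo sapiens) for cytotoxicity, read by MTT assay, with a stated time of 72 h; a higher number here means a weaker inhibitor, a lower number a stronger inhibitor. In this assay compound 1 gives > 200000 nM, which is a limit of the assay and not a measured number. Compound 2 `COc1ccc(NC(=O)COC(=O)/C=C/c2cc(OC)c(OCc3ccccc3)c(OC)c2)cc1` carries phenyl in place of 3,4-dichlorophenyl on a saturated chain carbon bound to an oxygen on an aromatic ring. In this assay compound 2 gives > 200000 nM, again a limit. The step that the two limits leave unreadable from compound 1 to compound 2 is accordingly unreadable, with both values sitting at the limit of > 200000 nM in this assay, at which 2 of the 2 values shown sit.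

Compound 3 `COc1cc(/C=C/C(=O)OCC(=O)Nc2ccc(Cl)cc2)cc(OC)c1OCc1ccc(Cl)c(Cl)c1` keeps the shared core of compound 1 and differs only by chloro in place of methoxy on an aromatic carbon. Going by the values given here, no measured step touches this part of the molecule, and the single measured step is itself unreadable, so the data offer no direction for the change; with both known values at the limit, the most that can be said is that compound 3 will probably also sit at or near the limit. Compound 3 is therefore estimated at 200000 nM in this assay, expected to fall between 50000 nM and 800000 nM, an expected step of a number no higher from compound 1 to compound 3 (the limit leaves the size open).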

Compound 3, half-maximal inhibitory concentration: > 200000 nM
Compound 3: only a limit was reported (the forecaster's own chance of this, stated with the estimate: 75%); the middle value sits exactly at the limit.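

Compound 3, like compound 1, gives only a limit in this assay, so the step between these two compounds cannot be read, and neither can the step from compound 1 to compound 2: the limit of > 200000 nM in this assay, at which 3 of the 3 values shown sit.

The compounds shown leave open whether chloro in place of methoxy changes the effect on these cells at all, and which structure in this assay would give a measured number.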